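The compounds below may be only part of what the source reports. "The series", "measured", "known", "first", "only" and "open" are said of these compounds alone.

Of the compounds shown here, three that share one core have been measured in an ADME assay (Rattus norvegicus) for metabolic stability; a higher number here means that more of the compound is left, a lower number that less of the compound is left. Compound 1 `Cc1nc(N[C@@H]2C[C@H]3CC[C@@H]2C3)c2cc(-c3cc(Cl)cc(Cl)c3)ccc2n1` gives 37%. Compound 2 `Cc1nc(N[C@@H]2C[C@H]3CC[C@@H]2C3)c2cc(-c3cccc(C(F)(F)F)c3)ccc2n1` gives 41%. Compound 3 `Clc1cc(Cl)cc(-c2ccc3nc(Cl)nc(N[C@@H]4C[C@H]5CC[C@@H]4C5)c3c2)c1` gives 76%. Compound 3 differs from compound 1 by a single change, (chloro in place of methyl on an aromatic carbon), and that change made a step of a number 39 percentage points higher from compound 1 to compound 3 (beyond the scatter). Compound 2 and compound 1 lie within the scatter of each other; how their two cores differ is not broken down here. Set against compound 3, compound 2 shows a number that is lower by more than the scatter.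

A fourth compound, compound 4 `FC(F)(F)c1cccc(-c2ccc3nc(Cl)nc(N[C@@H]4C[C@H]5CC[C@@H]4C5)c3c2)c1`, has not yet been measured in this assay. For the measured compounds named here, it differs from compound 2 by chloro in place of methyl on an aromatic carbon, which is the same change, at the same place, as the one that leads from compound 1 to compound 3. Going by the values given here, the expectation for compound 4 rests on the only step of this kind that is known: because that step was a number 39 percentage points higher from compound 1 to compound 3 (beyond the scatter), a step of roughly the same size, a number 37 percentage points higher from compound 2 to compound 4 (beyond the scatter), is expected in this assay. Whether the change acts alike on the core of compound 2 is not shown by these data, so the range is kept wide. Compound 4 is estimated at 78%, with a likely span from 60% to 92%.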

Compound 4, percent of the compound remaining: 67%
Compound 4: middle estimate off by 11 percentage points, on the high side; the range from low to high includes it.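

In this assay, chloro in place of methyl on the aromatic carbon between two ring nitrogen atoms again raised the result, with a number 26 percentage points higher from compound 2 to compound 4 (beyond the scatter), so the gain seen on the core of compound 1 also appears on the core of compound 2. The two steps point the same way and cannot be told apart in size, so within this pair of cores the change carried over: the same change on two cores in this assay, a number 39 percentage points higher (beyond the scatter) from compound 1 to compound 3 and a number 26 percentage points higher (beyond the scatter) from compound 2 to compound 4, 13 percentage points apart, within the scatter of two such steps. For the compounds shown here, this rests on only two cores, however, so it does not show that the step would hold on further cores, and it does not establish a fixed size for the step or explain why the change raises the result.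

Only methyl and chloro appear on that carbon, which leaves open how a methoxy group, an amine or a nitrile in the same place would compare in this assay. The compounds also leave open whether the chloro step would persist if the bridged amine substituent shared by all four compounds gave way to a different group, such as a simple open chain amine.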